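The source may hold more compounds than are shown below. What is called first, only, known or untested is meant among the compounds shown, and "the series" means these compounds.

Compound 1 `COC(=O)C1=C(CN2CC3CC2CO3)NC(c2nccs2)=NC1(C)c1ccc(F)cc1`: 84 mL/min/kg
Compound 2 `COC(=O)C1=C(CN2CCNC(=O)C2)NC(c2nccs2)=NC1(C)c1ccc(F)cc1`: 81 mL/min/kg
Compound 3 `COC(=O)C1=C(CN2CC(OC)C2)NC(c2nccs2)=NC1(C)c1ccc(F)cc1`: 88 mL/min/kg

All three were tested in an ADME assay on microsomes from liver (Mus musculus) for metabolic stability, read by LC-MS, using NADPH, with stated times of 10 min and 30 min, tested at 1 uM; on this read-out lower numbers stand for slow clearance and higher numbers for fast clearance. On these numbers, compound 3 at 88 mL/min/kg cannot be told apart from the other two.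

Compound 4 `COC(=O)C1=C(COC2CCOC2)NC(c2nccs2)=NC1(C)c1ccc(F)cc1` differs from compound 3 by (oxolan-3-yl)oxy in place of 3-methoxyazetidin-1-yl on a saturated chain carbon bound to a double-bonded ring carbon. Here (oxolan-3-yl)oxy replaces 3-methoxyazetidin-1-yl on a saturated chain carbon bound to a double-bonded ring carbon.

Three measured steps changed the group at this place: a 1.0-fold lower number from compound 1 to compound 2 (0.02 log units; within the scatter), a 1.0-fold higher number from compound 1 to compound 3 (0.02 log units; within the scatter) and a 1.1-fold higher number from compound 2 to compound 3 (0.04 log units; within the scatter). All stayed within the scatter, although none introduced this exact group. No step beyond the scatter is therefore expected in this assay.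

The expected step is a 1.1-fold lower number from compound 3 to compound 4 (0.04 log units; within the scatter).

For compound 4 the estimate is 80 mL/min/kg, with an expected range of 55 mL/min/kg to 105 mL/min/kg.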

Compound 4, clearance: 79 mL/min/kg
Estimate against measurement, compound 4: 1.0-fold (0.01 log units) above; the measured number falls inside the stated range.
By their numbers in this assay, from the lowest: compounds 4, 2, 1 and 3 (each within the scatter of the next).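

Each group seen earlier at this place held a nitrogen, while (oxolan-3-yl)oxy has only carbon and oxygen. Even so, this assay gives a 1.1-fold lower number from compound 3 to compound 4 (0.05 log units; within the scatter), a 1.0-fold lower number from compound 2 to compound 4 (0.01 log units; within the scatter) and a 1.1-fold lower number from compound 1 to compound 4 (0.03 log units; within the scatter). A group without nitrogen therefore cannot be told apart from the three with it on this read-out. Nothing measured here explains this lack of separation. Going by these compounds, whether a carboxylic acid or a primary amine on a longer chain at this place would give a step beyond the scatter remains open.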